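This account rests on a few compounds, and the source may have more. Where it says the series, first, only, none or still open, it means among the compounds named here.

Measured so far in a functional assay on Huh-7 cells (Homo sapiens) for cytotoxicity, read by CCK-8 assay, with a stated time of 72 h; a lower number here means a stronger inhibitor, a higher number a weaker inhibitor:
compound 1 `C=CCn1c(=O)/c(=C\c2ccccc2OC)[nH]c(=O)/c1=C\c1ccccc1OC` — 21200 nM
compound 2 `C=CCn1c(=O)/c(=C\c2cccc(Br)c2)[nH]c(=O)/c1=C\c1ccccc1OC` — 2300 nM
compound 3 `C=CCn1c(=O)/c(=C\c2ccc(C)cc2)[nH]c(=O)/c1=C\c1ccccc1OC` — "not active" (no number reported)

Compound 3 stands apart from the other two: in this assay compound 3 is recorded only as "not active" (no number reported), with no single number, so its position relative to compound 1 and compound 2 cannot be placed in figures. Compound 4 `C=CCn1c(=O)/c(=C\c2cccc(C)c2)[nH]c(=O)/c1=C\c1ccccc1OC` differs from compound 3 only in the aryl group: 3-methylphenyl in place of 4-methylphenyl on a double-bonded chain carbon bound to an aromatic carbon. Among the compounds with values here, no measured step covers this rearrangement. Within the data shown here, the one step that bears on it at all is a 9.2-fold lower number from compound 1 to compound 2 (0.96 log units; beyond the scatter), which shows that a 3-bromophenyl went with a markedly lower number in this assay than the 2-methoxyphenyl of compound 1. Compound 2 thus suggests that a 3-substituted phenyl can give a measurable number where compound 3, carrying 4-methylphenyl, gave none. Because compound 2 gives 2300 nM while compound 3 gives "not active" (no number reported), compound 4 is expected to land somewhere between those outcomes, with a real chance that no number is returned at all. For compound 4 the expected value in this assay is 12000 nM, with a range from 2500 nM to 60000 nM.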

Compound 4, half-maximal inhibitory concentration: 21400 nM
The estimate for compound 4 lay 1.8-fold (0.25 log units) below the measured number, within the range that was stated.
By their numbers in this assay, from the lowest: compound 2; then compounds 1 and 4 (each within the scatter of the next).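

In this assay the aryl group on the double-bonded chain carbon bound to an aromatic carbon now has a direct comparison, with a 9.3-fold higher number from compound 2 to compound 4 (0.97 log units; beyond the scatter) for methyl in place of bromo on an aromatic carbon, so the low number of compound 2 does not carry over to every 3-substituted phenyl in this set. With a 1.0-fold higher number from compound 1 to compound 4 (0.00 log units; within the scatter) and that step within the scatter, 3-methylphenyl and 2-methoxyphenyl cannot be told apart here, and the bromo compound remains the only one of the three with a number clearly set apart. The methyl rearrangement does register as a difference in outcome, since compound 3 is recorded as "not active" (no number reported) while compound 4 gives 21400 nM with the same atoms joined differently. Nothing available explains any of these differences.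

As far as these compounds go, it remains open whether the lower number belongs to bromo alone or would also appear with chloro, an amine or a carboxylic acid on that aromatic carbon. From the compounds shown here alone, it is also open whether a 4-bromophenyl would return a number, given the outcome for the 4-methylphenyl of compound 3.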